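The compounds below may be only part of what the source reports. "The series", "measured", "known", "first", "only" and "open" are said of these compounds alone.

Measured compounds:
compound 1 `CC1=C(C(=O)OC(C)C)C(c2cccc([N+](=O)[O-])c2)NC(=S)N1` — 10700 nM
compound 2 `COC(=O)N1C(=O)NC(C)=C(C(=O)OC(C)C)C1c1cccc([N+](=O)[O-])c1` — 2480 nM
compound 3 `COC(=O)N1C(=S)NC(C)=C(C(=O)OC(C)C)C1c1cccc([N+](=O)[O-])c1` — 350 nM

In an assay on HEK293 cells for antagonist activity at Voltage-dependent L-type calcium channel subunit alpha-1C (Oryctolagus cuniculus), read by FLIPR (a higher number here means a weaker inhibitor, a lower number a stronger inhibitor), compound 1 gives 10700 nM, while compound 3 `COC(=O)N1C(=S)NC(C)=C(C(=O)OC(C)C)C1c1cccc([N+](=O)[O-])c1` gives 350 nM. The change between them is methoxycarbonyl in place of hydrogen on an amide-type nitrogen in a ring, and it produced a 31-fold lower number from compound 1 to compound 3 (1.49 log units; beyond the scatter). Compound 2 `COC(=O)N1C(=O)NC(C)=C(C(=O)OC(C)C)C1c1cccc([N+](=O)[O-])c1` gives 2480 nM; how its core differs from that of compound 1 is not broken down here. Compound 4 `COC(=O)N1C(=O)N(C(=O)OC)C(c2cccc([N+](=O)[O-])c2)C(C(=O)OC(C)C)=C1C` is not yet measured. It differs from compound 2 by methoxycarbonyl in place of hydrogen on an amide-type nitrogen in a ring. This is the same kind of change as from compound 1 to compound 3, but not the same: there the nitrogen is next to the ring atom that bears a 3-nitrophenyl group, here next to the ring atom that bears a methyl group. Because a 31-fold lower number from compound 1 to compound 3 (1.49 log units; beyond the scatter) was large, compound 4 is expected to show a smaller but still favourable step, a 3.1-fold lower number from compound 2 to compound 4 (0.49 log units; beyond the scatter), with wide uncertainty given the different place. For compound 4 the estimate is 800 nM, between 200 nM and 4000 nM.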

Compound 4, half-maximal inhibitory concentration: 6130 nM
Beside the measured number, compound 4's estimate is 7.7-fold (0.88 log units) below it; measured number above the stated range.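

In this assay, methoxycarbonyl in place of hydrogen on an amide-type nitrogen in a ring gave a 2.5-fold higher number from compound 2 to compound 4 (0.39 log units; beyond the scatter), so the large gain seen on the first core did not carry over to the second. The two steps differ clearly: the same change on two cores in this assay, a 31-fold lower number (1.49 log units; beyond the scatter) from compound 1 to compound 3 and a 2.5-fold higher number (0.39 log units; beyond the scatter) from compound 2 to compound 4, 76-fold (1.88 log units) apart, beyond the scatter of two such steps This shows that the earlier step cannot be transferred to another core or ring nitrogen in this series, but it does not show whether the place of the nitrogen, the rest of the core or the methoxycarbonyl group already present in compound 2 decides the outcome.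

As far as these compounds go, it remains open how the same change would behave on compound 3. Also open, from the compounds shown here alone, is whether an acetyl group or a longer chain on that nitrogen would follow either step.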